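One Aryl Swap, One Cytotoxicity Estimate

The source may hold more compounds than are shown below. What is called first, only, known or untested is meant among the compounds shown, and "the series" means these compounds.

Measured compounds:
- compound 1 `COc1ccc(/C=C\C(=O)O)c(OCc2cn(-c3cccc(C#N)c3)nn2)c1CC=C(C)C`: 19200 nM
- compound 2 `COc1ccc(/C=C\C(=O)O)c(OCc2cn(-c3ccccc3)nn2)c1CC=C(C)C`: 34100 nM
- compound 3 `COc1ccc(/C=C\C(=O)O)c(OCc2cn(-c3cccnc3Cl)nn2)c1CC=C(C)C`: "not determined" (no result reported)

All three share one core and differ only in the aromatic group attached to the ring nitrogen. In a functional assay on T47D cells (Homo sapiens) for cytotoxicity, read by MTT assay, with a stated time of 24 h (on this read-out lower numbers stand for stronger inhibition and higher numbers for weaker inhibition), compound 1 gives 19200 nM, and in this assay compound 2 gives 34100 nM. Among the measured compounds shown here, the one step between them, a 1.8-fold higher number from compound 1 to compound 2 (0.25 log units; within the scatter), is too small to count as a real change. As far as these compounds go, compound 3 stands apart: in this assay compound 3 gives "not determined" (no result reported), so no single number was obtained for it and its place among the others is unknown.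

Compound 4 `COc1ccc(/C=C\C(=O)O)c(OCc2cn(-c3cccc([N+](=O)[O-])c3)nn2)c1CC=C(C)C` is the next step, in which (3-nitrophenyl in place of 2-chloropyridin-3-yl on an aromatic nitrogen). For the measured compounds named here, no measured step tracks this change directly. Going by the values given here, the only measured step, from compound 1 to compound 2, shows that removing a small group from the same aromatic ring left the read-out within the scatter, and compound 4 carries a different small group on a ring of the same kind as compounds 1 and 2. With compound 3 lacking a value, the expectation rests on compounds 1 and 2 alone: a number near theirs, with no direction favoured beyond the scatter.

Compound 4 is therefore expected to give about 24000 nM in this assay, estimated to fall between 8000 nM and 70000 nM.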

Compound 4, half-maximal inhibitory concentration: 15400 nM
Compound 4: the middle estimate sits 1.6-fold (0.19 log units) above what was measured; the range from low to high includes it.
By their numbers in this assay, from the lowest: compounds 4, 1 and 2 (each within the scatter of the next, the first and the last beyond it).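

In this assay, among the compounds shown here, adding nitro to the unsubstituted aromatic ring gives the first step that lies beyond the scatter: a 2.2-fold lower number from compound 2 to compound 4 (0.35 log units; beyond the scatter), although the change is only modest. Exchanging cyano for nitro on the same kind of ring makes no real difference, a 1.2-fold lower number from compound 1 to compound 4 (0.10 log units; within the scatter), so these two groups cannot be told apart in this assay, and the cyano step from the earlier pair stayed within the scatter. Nothing available explains why the nitro step clears the scatter when the cyano step does not.

As far as these compounds go, compound 3 has no value, so the swap from 2-chloropyridin-3-yl to 3-nitrophenyl cannot be read, and it remains unknown whether an aromatic ring containing a nitrogen behaves differently from one of carbon only. The compounds shown also leave open what an amine or a carboxylic acid on this ring would do, and whether any group at this position can move the read-out by more than the modest step seen here.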